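Ethoxy to isopropyl on the fused ring: compound 3

A few compounds are considered here, and "the series" means these few. Any claim that something is new, unique, unknown or untested is made for them only; others in the source may bear on it.

Measured so far:
- compound 1 `O=C(O)CCNC(=O)c1ccc(Cn2nc(-c3cc(Cl)cc(Cl)c3)cc2-c2ccc3c(OC(F)(F)F)cccc3c2)cc1`: 40.5 nM
- compound 2 `CCOc1ccc2cc(-c3cc(-c4cc(Cl)cc(Cl)c4)nn3[C@@H](C)c3ccc(C(=O)NCCC(=O)O)cc3)ccc2c1`: 8.1 nM

Both numbers come from an assay on CHO cells for displacement of a labelled ligand from Glucagon receptor (Homo sapiens), read by scintillation proximity assay, with a stated time of 3 h; on this read-out higher numbers stand for weaker inhibition and lower numbers for stronger inhibition. Among the measured compounds shown here, compound 2 holds the lower of the two numbers, and its only neighbour, compound 1, sits at a higher number by a margin beyond the usual scatter. For the measured compounds named here, no pair of measured compounds differs in just one place, so these two values give no calibrated single-change step; they show only that compound 2 is the stronger of the two.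

Compound 3 `CC(C)c1ccc2cc(-c3cc(-c4cc(Cl)cc(Cl)c4)nn3[C@@H](C)c3ccc(C(=O)NCCC(=O)O)cc3)ccc2c1` is compound 2 with isopropyl in place of ethoxy on an aromatic carbon. Going by the values given here, with no precedent for this kind of swap, the expected step in this assay is small, at most at the edge of the scatter, and if anything toward a higher number. Compound 3 is therefore expected at 12 nM, with a range of 4 nM to 40 nM. The estimated step of a 1.5-fold higher number from compound 2 to compound 3 (0.17 log units; within the scatter) is thus expected to stay modest.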

Compound 3, half-maximal inhibitory concentration: 4.3 nM
Compound 3: middle estimate off by 2.8-fold (0.45 log units), on the high side; the measured number falls inside the stated range.
By their numbers in this assay, from the lowest: compounds 3 and 2 (each within the scatter of the next); then compound 1.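

Among the compounds shown here, compound 2 and compound 3 form the first pair that differs in one place, so this aromatic carbon can now be read on its own. In this assay isopropyl in place of ethoxy gives a 1.9-fold lower number from compound 2 to compound 3 (0.28 log units; within the scatter) and the two groups cannot be told apart on this read-out. On this single pair, the ether oxygen and its hydrogen-bond acceptor leave with the ethoxy group without a step beyond the scatter, though no measurement at hand explains this result.

Open, as far as these compounds go, is how far this tolerance extends on the same carbon: a plain hydrogen, a tert-butyl group, an amine or a carboxylic acid could each behave differently. Also open, from the compounds shown here alone, is whether the same swap gives a similar step on the core of compound 1.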